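Replacing an aromatic sulfonyl group with butyl

The source may report more compounds than this note shows. Statements on the series, on what has been measured and on what is new or still open speak of the compounds shown alone.

Values in a functional assay on A549 cells (Homo sapiens) for antiproliferative activity, read by sulforhodamine B assay, with a stated time of 72 h; a higher number here means a weaker inhibitor, a lower number a stronger inhibitor:
- Compound 1 `CCOC(=O)c1cnc2ccc(-c3cnc(OC)c(NS(=O)(=O)c4ccc(F)cc4F)c3)cn12`: 300 nM
- Compound 2 `COc1ncc(-c2ccc3ncc(C(=O)O)n3c2)cc1NS(=O)(=O)c1ccc(F)cc1F`: 1150 nM
- Compound 3 `CCOC(=O)c1cc2cc(-c3cnc(OC)c(NS(=O)(=O)c4ccc(F)cc4)c3)ccc2[nH]1`: > 20000 nM, a limit of the assay

Compound 1 has the lower of the two exact numbers, 300 nM. Among the measured compounds shown here, the only measured step, a 3.8-fold higher number from compound 1 to compound 2 (0.58 log units; beyond the scatter), puts hydrogen in place of ethyl and leaves the sulfonyl sulfur untouched, so it offers only a rough scale. Compound 4 `CCCCS(=O)(=O)Nc1cc(-c2ccc3ncc(C(=O)OCC)n3c2)cnc1OC` has butyl in place of 2,4-difluorophenyl on a sulfonyl sulfur. With a whole ring leaving, a larger change than that step is expected, toward weaker inhibition in this assay. The expected step is a 10-fold higher number from compound 1 to compound 4 (1.00 log units; beyond the scatter). Compound 4 is estimated at 3000 nM, with an expected range from 700 nM to 15000 nM.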

Compound 4, half-maximal inhibitory concentration: 3560 nM
Beside the measured number, compound 4's estimate is 1.2-fold (0.07 log units) below it; the measured number falls inside the stated range.
By their numbers in this assay, from the lowest: compound 1; then compound 2; then compound 4. At a limit, above all of these: compound 3.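

In this assay, among the compounds shown here, the swap at the sulfonyl sulfur brings a 12-fold higher number from compound 1 to compound 4 (1.07 log units; beyond the scatter) and is the first measured step at this place, where the earlier step changed only the ester. The group on the sulfonyl sulfur therefore matters clearly for this read-out. Compound 4 still gives an exact number, so the 2,4-difluorophenyl ring is not essential for a measurable value here.

Going by these compounds, whether methyl, a longer chain or benzyl would stay closer to compound 1 remains open. Nothing measured here bears on the cause of this step.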